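This account rests on a few compounds, and the source may have more. Where it says the series, first, only, none or still open, it means among the compounds named here.

Working notes on the series in a functional assay on HGC cells (Homo sapiens) for cytotoxicity, read by MTT assay, with a stated time of 48 h; on this read-out higher numbers stand for weaker inhibition and lower numbers for stronger inhibition. Compound 1 (`CCn1c(/C=C2/C(=O)Nc3ccccc32)nc2ccccc21`) reads > 50000 nM, and this is a limit of the assay, not a number. Compound 2 (`CC(C)n1c(/C=C2/C(=O)Nc3ccccc32)nc2ccccc21`) gives 33500 nM. Among the measured compounds shown here, the only measured step is an at least 1.4-fold lower number from compound 1 to compound 2 (0.17 log units; that floor lies within the scatter).

Compound 3 (`Cn1c(/C=C2/C(=O)Nc3ccc([N+](=O)[O-])cc32)nc2ccccc21`) offers no starting number, since its entry is "not determined" (no result reported). Its place in the series is therefore unknown on these data.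

The next change leads to compound 4 (`Cn1c(/C=C2/C(=O)Nc3ccc(Cl)cc32)nc2ccccc21`) and is chloro in place of nitro on an aromatic carbon. For the measured compounds named here, the one measured step sits on a saturated chain carbon bound to the aromatic nitrogen, not on this aromatic carbon, so it does not bear directly on the change and gives no size for it. With no value for compound 3, no size or direction can be assigned to the change in this assay either.

Going by the values given here, the expectation can rest only on the general level of the series, where compound 2 at 33500 nM is the single true number. Weak inhibition is expected, with a real chance of another limit reading. Compound 4 is estimated at 28000 nM, with an expected range of 10000 nM to 50000 nM.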

Compound 4, half-maximal inhibitory concentration: 43600 nM
Compound 4: middle estimate off by 1.6-fold (0.19 log units), on the low side, and the stated range covers the measured number.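

No step can be read between compound 3 and compound 4: compound 3 carries no value in this assay, and compound 4 stands alone at 43600 nM. The compounds shown leave open how chloro and nitro compare on this aromatic carbon, and whether any change there moves the reading beyond the usual scatter.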